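Swapping a Thiadiazole for a Triazole on the Shared Core

The source may hold more compounds than are shown below. What is called first, only, known or untested is meant among the compounds shown, and "the series" means these compounds.

Compound 1, `Cc1nnc(Sc2cc(NC(=O)c3ccc(Cl)cc3)c3ccccc3c2O)s1`: > 100000 nM in a functional assay on MDA-MB-231 cells (Homo sapiens) for antiproliferative activity, read by MTT assay, with a stated time of 48 h (a higher number here means a weaker inhibitor, a lower number a stronger inhibitor), a limit of the assay.
Compound 2, `COc1ccc(/C=C/C(=O)Nc2cc(Sc3ncn[nH]3)c(O)c3ccccc23)cc1OC`: 52500 nM.
Compound 3, `O=C(Nc1cc(Sc2ncnc3nc[nH]c23)c(O)c2ccccc12)c1ccc([N+](=O)[O-])cc1`: > 100000 nM, a limit of the assay.

Compound 1 stands at the limit of > 100000 nM in this assay, at which 2 of the 3 values shown sit, so no number is known for it, only that it is a weak inhibitor beyond the reach of this assay. Compound 3 sits at the same limit. Among the compounds with values here, compound 2 is the only compound of the three with a numeric value.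

Compound 4, `O=C(Nc1cc(Sc2ncn[nH]2)c(O)c2ccccc12)c1ccc(Cl)cc1`, has not yet been measured. It differs from compound 1 in one place: 1H-1,2,4-triazol-5-yl in place of 5-methyl-1,3,4-thiadiazol-2-yl on a sulfur. Compound 2 carries the same 1H-1,2,4-triazol-5-yl on a sulfur, and its value is a number rather than a limit, whereas compound 1 and compound 3 both sit at the limit.

The step from compound 1 to compound 4 is expected to be modest, towards a stronger inhibitor, with an at least 1.2-fold lower number from compound 1 to compound 4 (0.09 log units; that floor lies within the scatter) as the estimate. Compound 4 is therefore expected to give about 80000 nM, somewhere between 30000 nM and 200000 nM, with a fair chance that the assay again reports only a limit.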

Compound 4, half-maximal inhibitory concentration: 25700 nM
Compound 4: the middle estimate sits 3.1-fold (0.49 log units) above what was measured; measured number below the stated range.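

In this assay, the group on the sulfur turns out to matter on this shared core: with everything else held the same, 1H-1,2,4-triazol-5-yl in place of 5-methyl-1,3,4-thiadiazol-2-yl gives an at least 3.8-fold lower number from compound 1 to compound 4 (0.59 log units; beyond the scatter) and brings the compound into the range where the assay reports a number. This step is a floor and not an exact size, because compound 1 gives only a limit of the assay: the limit of > 100000 nM in this assay, at which 2 of the 4 values shown sit. The two rings differ in several ways at once, since the entering ring has a hydrogen-bond donor that the leaving ring lacks, and it has no ring sulfur and no methyl group, so this single pair cannot show which of these differences accounts for the step.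

An unsubstituted 1,3,4-thiadiazol-2-yl or a 1,2,4-triazole carrying a methyl group on the same sulfur would help separate these differences, and the compounds shown include neither. As far as these compounds go, it also remains open whether an amine or a carboxylic acid on the triazole ring would move the value further in either direction.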